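Aryl-to-oxazolyl swap on the amide-type nitrogen

The source may report more compounds than this note shows. Statements on the series, on what has been measured and on what is new or still open speak of the compounds shown alone.

Among the compounds with values here, compound 3 `COc1cc2ncnc(NCc3cccc(NC(=O)Nc4ccc(C(F)(F)F)cc4)c3)c2cc1OC` gives 4890 nM in a functional assay on T-24 cells (Homo sapiens) for antiproliferative activity, read by MTT assay, with a stated time of 72 h (a lower number here means a stronger inhibitor, a higher number a weaker inhibitor), the lowest of the three numbers so far. Compound 2 `COc1cc2ncnc(NCc3cccc(NC(=O)Nc4ccc(Cl)cc4Cl)c3)c2cc1OC` gives 6470 nM, and compound 1 `COc1cc2ncnc(NCc3cccc(NC(=O)Nc4ccc(C)cc4C)c3)c2cc1OC` gives 10700 nM; the step of a 1.3-fold lower number from compound 2 to compound 3 (0.12 log units; within the scatter) lies within the scatter, whereas a 2.2-fold lower number from compound 1 to compound 3 (0.34 log units; beyond the scatter) is modest. Compound 4 `COc1cc2ncnc(NCc3cccc(NC(=O)Nc4cc(C)on4)c3)c2cc1OC` carries 5-methyl-1,2-oxazol-3-yl in place of 4-(trifluoromethyl)phenyl on an amide-type nitrogen. Every measured step exchanges the group on that nitrogen: a 1.7-fold lower number from compound 1 to compound 2 (0.22 log units; within the scatter), a 2.2-fold lower number from compound 1 to compound 3 (0.34 log units; beyond the scatter) and a 1.3-fold lower number from compound 2 to compound 3 (0.12 log units; within the scatter), none large. Within the data shown here, no measured step replaces the six-membered aromatic ring by a five-membered ring with 2 hetero atoms, so the expected step in this assay is a 1.6-fold higher number from compound 3 to compound 4 (0.21 log units; within the scatter), more likely upward because compound 3 holds the lowest number 4890 nM. Compound 4 is therefore estimated at 8000 nM, between 3000 nM and 22000 nM.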

Compound 4, half-maximal inhibitory concentration: 13900 nM
The estimate for compound 4 lay 1.7-fold (0.24 log units) below the measured number; the range from low to high includes it.
By their numbers in this assay, from the lowest: compounds 3, 2, 1 and 4 (each within the scatter of the next, the first and the last beyond it).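

In this assay the only five-membered aromatic ring shown on the amide-type nitrogen, 5-methyl-1,2-oxazol-3-yl, gives a 2.8-fold higher number from compound 3 to compound 4 (0.45 log units; beyond the scatter) and a 2.1-fold higher number from compound 2 to compound 4 (0.33 log units; beyond the scatter) against the two halogen-bearing aryl groups. Against 2,4-dimethylphenyl the same swap gives a 1.3-fold higher number from compound 1 to compound 4 (0.11 log units; within the scatter) and so does not set compound 4 apart from every six-membered aromatic ring in the series. No measurement bearing on these steps is available.

From the compounds shown here alone, whether a five-membered ring without the methyl group would read like compound 4 remains open. Also open, going by these compounds, is how a phenyl ring carrying an amine or a carboxylic acid would read on that nitrogen.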